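Adding a third methoxy group to a triazole oxime amide

The source may hold more compounds than are shown below. What is called first, only, known or untested is meant among the compounds shown, and "the series" means these compounds.

Compound 1 `COc1ccc(-c2nnc(SCC(=O)Nc3ccc(/C(C)=N/O)cc3)n2-c2ccccc2)cc1`, compound 2 `COc1ccc(-c2nnc(SCC(=O)Nc3ccc(/C(C)=N/O)cc3)n2-c2ccccc2)cc1OC` and compound 3 `C=CCn1c(SCC(=O)Nc2ccc(/C(C)=N/O)cc2)nnc1-c1ccc(OC)c(OC)c1` were all tested in a functional assay on the whole organism (strain albino) for inhibition, with Rattus norvegicus as the target, read by paw edema, with stated times of 30 min and 4 h, at a dose of 0.28 mmol/kg by the oral route; a lower number here means less inhibition, a higher number more inhibition at the dose given (going by the name of the read-out). Compound 1 gives 69%, compound 2 gives 79% and compound 3 gives 79%. Compound 2 differs from compound 1 by methoxy in place of hydrogen on an aromatic carbon, and the result was a number 10 percentage points higher from compound 1 to compound 2 (within the scatter). Compound 3 differs from compound 2 only by allyl in place of phenyl on an aromatic nitrogen, with no change at the digits printed from compound 2 to compound 3 (within the scatter). The difference between the cores of compound 1 and compound 3 is not broken down here.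

Compound 4 `C=CCn1c(SCC(=O)Nc2ccc(/C(C)=N/O)cc2)nnc1-c1cc(OC)c(OC)c(OC)c1` has not yet been measured. It differs from compound 3 by methoxy in place of hydrogen on an aromatic carbon. Going by the values given here, this is the same kind of change as the one from compound 1 to compound 2, though the surroundings are not identical: in compound 4 the entering group is also meta to a methoxy group. Because the earlier step was a number 10 percentage points higher from compound 1 to compound 2 (within the scatter), a step of similar size, a number 3 percentage points higher from compound 3 to compound 4 (within the scatter), is expected here. Compound 4 is therefore estimated at 82%, with a likely range from 70% to 93%.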

Compound 4, a percentage reported as inhibition, in the whole organism at one dose (the size of the read-out at that dose, not a potency): 72%
For compound 4 the middle estimate is 10 percentage points above the measured one, and the stated range covers the measured number.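

In this assay, methoxy in place of hydrogen on an aromatic carbon gives a number 7 percentage points lower from compound 3 to compound 4 (within the scatter). Set beside the earlier case, this shows that the same change does not bring a step of the same size on both cores, so the earlier step is a poor guide to the later one: the same change on two cores in this assay, a number 10 percentage points higher (within the scatter) from compound 1 to compound 2 and a number 7 percentage points lower (within the scatter) from compound 3 to compound 4, 17 percentage points apart, beyond the scatter of two such steps It does not show that methoxy reliably raises or lowers inhibition on either core, since each step alone lies within the scatter, and two pairs in which the surroundings of the entering group differ give no general rule and no explanation.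

The compounds shown leave open what the same added methoxy would do with phenyl rather than allyl on the aromatic nitrogen, which would separate the effect of that group from the effect of the methoxy pattern. They also leave open how a hydroxyl group or a chlorine atom would compare with methoxy at this place on the ring, and how a longer chain such as butyl would compare with allyl.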